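A few compounds are considered here, and "the series" means these few. Any claim that something is new, unique, unknown or untested is made for them only; others in the source may bear on it.

Measured compounds:
compound 1, `CCCNc1nc2ccc(-c3cnc(Cl)c(NS(=O)(=O)c4ccc(F)cc4)c3)cc2s1` — "not determined" (no result reported) in a functional assay on U-87MG ATCC cells for antiproliferative activity against U-87 MG (Homo sapiens), read by MTT assay, with a stated time of 72 h; a lower number here means a stronger inhibitor, a higher number a weaker inhibitor.
compound 2, `COc1ncc(-c2ccc3nc(NC4CC4)sc3c2)cc1NS(=O)(=O)c1ccc(F)cc1` — 1500 nM.

Within the data shown here, compound 2 is the only member of this pair with a number in this assay: compound 2 gives 1500 nM, and compound 1 contributes no value, so compound 2 stands alone and cannot be ranked against anything.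

The unmeasured compound 3, `CCN(CC)CCNC(=O)Nc1nc2ccc(-c3cnc(OC)c(NS(=O)(=O)c4ccc(F)cc4)c3)cc2s1`, is reached from compound 2 by one change: (2-(diethylamino)ethyl)carbamoyl in place of cyclopropyl on a nitrogen on an aromatic ring. Cut one bond further out, the change reads cyclopropylamino to ((2-(diethylamino)ethyl)carbamoyl)amino, on a nitrogen on an aromatic ring whose other neighbour is an aromatic carbon.

Among the measured compounds shown here, no measured pair in this set shares that kind of change, so there is nothing from which to read a direction. The step of a 1.3-fold higher number from compound 2 to compound 3 (0.12 log units; within the scatter) is therefore expected to stay within the usual scatter of this assay, with no clear gain or loss. Compound 3 is estimated at 2000 nM, in a range from 600 nM to 7000 nM.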

Compound 3, half-maximal inhibitory concentration: 390 nM
The estimate for compound 3 lay 5.1-fold (0.71 log units) above the measured number; measured number outside the range, below it.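

In this assay, the nitrogen on the aromatic ring accepts a much larger group than cyclopropyl: (2-(diethylamino)ethyl)carbamoyl in its place gives a 3.8-fold lower number from compound 2 to compound 3 (0.59 log units; beyond the scatter), a step beyond the scatter. Among these compounds, this is the first sign that the number responds to a change at this position, and the open-chain group, which has no ring and adds a hydrogen-bond donor and hydrogen-bond acceptors, is not penalised in this assay. Nothing shown bears on the reason for this step.

The compounds shown leave open which part of the entering group matters, as a plain ethylcarbamoyl or a morpholine in place of the diethylamino would separate the carbamoyl from the amine. On these data alone, it also remains open whether the same change would hold with chloro in place of methoxy on the shared core.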